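The source may hold more compounds than are shown below. What is called first, only, known or untested is meant among the compounds shown, and "the series" means these compounds.

Compound 1 `O=Cc1ccc(-c2cn3ccnc3c(-c3ccc4ncn(C5CCCCC5)c4c3)n2)cc1`: 23.1%
Compound 2 `Fc1ccc(-c2cn3ccnc3c(-c3ccc4ncn(C5CCCCC5)c4c3)n2)cc1`: 7.93%
Compound 3 `Clc1ccc(-c2cn3ccnc3c(-c3ccc4ncn(C5CCCCC5)c4c3)n2)cc1`: 14.5%

All three share one core and differ only in the group on the outer phenyl ring, and all were tested in a functional assay on SF-295 cells (Homo sapiens) for inhibition, read by sulforhodamine B assay, with a stated time of 48 h, tested at 10 uM; a higher number here means more inhibition at the concentration tested (going by the name of the read-out), a lower number less inhibition. Compound 3 holds the second highest of the three numbers. Its nearest neighbour is compound 2, and the step of a number 6.6 percentage points higher from compound 2 to compound 3 (within the scatter) stays within the scatter of this assay. The furthest is compound 1, yet even the step of a number 8.6 percentage points lower from compound 1 to compound 3 (within the scatter) lies within the scatter, so none of these three can be set apart from compound 3 with confidence.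

The next compound, compound 4 `Fc1ccccc1-c1cn2ccnc2c(-c2ccc3ncn(C4CCCCC4)c3c2)n1`, is reached by the change (2-fluorophenyl in place of 4-chlorophenyl on an aromatic carbon). Among the measured compounds shown here, two measured steps bear on it. The step of a number 6.6 percentage points higher from compound 2 to compound 3 (within the scatter) shows that swapping chloro for fluoro at the same position made no difference beyond the scatter. The step of a number 15.2 percentage points lower from compound 1 to compound 2 (beyond the scatter) was modest and involved formyl, which is absent here. For the measured compounds named here, no measured pair moves the halogen to a different position on the phenyl ring, so that part of the change is untested. The expectation is therefore a step of a number 3.5 percentage points lower from compound 3 to compound 4 (within the scatter) that stays within the scatter. For compound 4 the estimated value is 11%, with a range from 0% to 25%.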

Compound 4, a percentage reported as inhibition, at one concentration (the size of the read-out at that concentration, not a potency): 10.4%
Estimate against measurement, compound 4: 0.6 percentage points above, within the range that was stated.
By their numbers in this assay, from the lowest: compounds 2, 4, 3 and 1 (each within the scatter of the next, the first and the last beyond it).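

Placing the halogen as 2-fluorophenyl rather than 4-fluorophenyl gives the first view of a different position on the outer ring, and in this assay the step of a number 2.5 percentage points higher from compound 2 to compound 4 (within the scatter) shows no change that can be told from the scatter, just as the step of a number 4.1 percentage points lower from compound 3 to compound 4 (within the scatter) does for the swap from 4-chlorophenyl. The gap to the formyl compound is clearer, since the step of a number 12.7 percentage points lower from compound 1 to compound 4 (beyond the scatter) is modest but joins the step of a number 15.2 percentage points lower from compound 1 to compound 2 (beyond the scatter) in setting compound 1 apart from the two fluoro compounds, while compound 3 goes against this pattern with the step of a number 8.6 percentage points lower from compound 1 to compound 3 (within the scatter) inside the scatter. Nothing measured here offers a reason for these numbers.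

The compounds shown carry only a halogen or a formyl group on the outer phenyl ring, so it remains open what an amine, a carboxylic acid or a longer chain would do at this place. A 2-chlorophenyl group would also be needed to show whether the position and the identity of the halogen matter separately, and a single tested concentration gives no potency for any of these compounds.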